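The compounds below may be only part of what the source reports. "The series", "measured", "known", "first", "only" and "open" are said of these compounds alone.

Measured so far:
compound 1 `Nc1nc(N)c2cc(CSC(=S)N3CCN(c4ccc(O)cc4)CC3)ccc2n1`: 5980 nM
compound 2 `Cc1ccc(N2CCN(C(=S)SCc3ccc4nc(N)nc(N)c4c3)CC2)c(C)c1`: 4070 nM

In a functional assay on HCT-116 cells (Homo sapiens) for antiproliferative activity, read by MTT assay, with a stated time of 72 h (a lower number here means a stronger inhibitor, a higher number a weaker inhibitor), compound 1 gives 5980 nM, the higher of the two numbers; its nearest neighbour is compound 2 at 4070 nM, and the step of a 1.5-fold lower number from compound 1 to compound 2 (0.17 log units; within the scatter) stays within the scatter. Compound 3 `Nc1nc(N)c2cc(CSC(=S)N3CCN(c4ccc([N+](=O)[O-])cc4)CC3)ccc2n1` differs from compound 1 by nitro in place of hydroxy on an aromatic carbon. Going by the values given here, no measured step covers this change; the single step available is the aryl swap from compound 1 to compound 2, which was within scatter, so no step beyond the scatter is expected in this assay and a 1.2-fold lower number from compound 1 to compound 3 (0.08 log units; within the scatter) is the estimate. Compound 3 is therefore expected near 5000 nM, within 2000 nM to 15000 nM.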

Compound 3, half-maximal inhibitory concentration: 4680 nM
Beside the measured number, compound 3's estimate is 1.1-fold (0.03 log units) above it, and the stated range covers the measured number.
By their numbers in this assay, from the lowest: compounds 2, 3 and 1 (each within the scatter of the next).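

In this assay, the para position of the aryl ring on the piperazine-free reading is best put plainly: nitro in place of hydroxy gives a 1.3-fold lower number from compound 1 to compound 3 (0.11 log units; within the scatter), and 4-nitrophenyl in place of 2,4-dimethylphenyl gives a 1.1-fold higher number from compound 2 to compound 3 (0.06 log units; within the scatter). The hydrogen-bond donor of the hydroxy group is therefore not needed to hold the number at this level, since the aryl groups with and without it stay within the scatter of one another. Nothing available explains this flat response. As far as these compounds go, whether an amine or a carboxylic acid at this position, or a longer chain in place of the aryl group, would give a step beyond the scatter remains open.

Correction to the opening clause, as a clean final version: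

In this assay, the position para to a large group accepts a further change: nitro in place of hydroxy gives a 1.3-fold lower number from compound 1 to compound 3 (0.11 log units; within the scatter), and 4-nitrophenyl in place of 2,4-dimethylphenyl gives a 1.1-fold higher number from compound 2 to compound 3 (0.06 log units; within the scatter). The hydrogen-bond donor of the hydroxy group is not needed to hold the number at this level, since aryl groups with and without it stay within the scatter of one another. Nothing available explains this flat response. From the compounds shown here alone, whether an amine or a carboxylic acid at this position, or a longer chain in place of the aryl group, would give a step beyond the scatter remains open.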